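This account rests on a few compounds, and the source may have more. Where it says the series, first, only, none or still open, it means among the compounds named here.

Measured compounds in a functional assay on HCT-116 cells (Homo sapiens) for inhibition, read by MTT assay, with a stated time of 72 h; a higher number here means a weaker inhibitor of growth, a lower number a stronger inhibitor of growth:
- compound 1 `CN1CCN(C(=O)/C=C/c2ccncc2-c2ccc3ccccc3c2)CC1`: > 30000 nM
- compound 2 `CCOC(=O)/C=C/c1ccncc1-c1ccc2c(cnn2C)c1`: 1330 nM
- compound 3 `COC1CN(C(=O)/C=C/c2ccncc2-c2ccc(F)cc2)C1`: "not determined" (no result reported)

Compound 1 stands at a limit of this assay, not at a number: its reading of > 30000 nM is the value at which one of the three entries sits (the limit of > 30000 nM in this assay, at which 1 of the 3 values shown sits). Compound 2 in this assay gives 1330 nM, a plain number, and compound 3 gives nothing. For the measured compounds named here, no step between two measured compounds that differ in one place is available, so nothing here calibrates the size of any single change.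

Compound 4 `CCOC(=O)/C=C/c1ccncc1-c1ccc2ccccc2c1` is not yet measured. It differs from compound 1 in one place:
ethoxy in place of 4-methylpiperazin-1-yl on a carbonyl carbon
Going by the values given here, the only measured ethoxycarbonyl compound, compound 2 at 1330 nM, carries a different ring system on the shared core, so it is a loose guide at best. Still, the expected step in this assay from compound 1 to compound 4 is toward stronger growth inhibition, beyond the scatter, estimated as an at least 12-fold lower number from compound 1 to compound 4 (1.07 log units; beyond the scatter). Compound 4 is therefore expected to give about 2500 nM, within 500 nM to 20000 nM.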

Compound 4, concentration for 50% growth inhibition: 910 nM
Compound 4: middle estimate off by 2.7-fold (0.44 log units), on the high side; low and high end bracket the measured number.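

In this assay, for the compounds shown here, ethoxy in place of 4-methylpiperazin-1-yl on a carbonyl carbon gives an at least 32-fold lower number from compound 1 to compound 4 (1.51 log units; beyond the scatter), the only step that sizes a single change at this position. With the rest of the structure held fixed, growth inhibition in this pair depends strongly on the group on the carbonyl carbon. The step has a floor but no ceiling, and its true size remains unknown, as compound 1 stands at a limit of the assay: the limit of > 30000 nM in this assay, at which 1 of the 4 values shown sits.

One pair cannot separate the contributions of the ring, the two nitrogen atoms and the change from amide to ester. A dimethylamino group on the same carbonyl carbon, a carboxylic acid or a longer butoxy chain would help separate them.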